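This account rests on a few compounds, and the source may have more. Where it says the series, first, only, none or still open, it means among the compounds named here.

Series notes. Compound 1 `Nc1ccccc1NC(=O)c1ccc(CSC(=S)N2CCN(c3cccnc3)CC2)cc1` stands highest of the two numbers in a functional assay on MGC-803 cells (Homo sapiens) for antiproliferative activity, read by CCK-8 assay, with a stated time of 72 h, tested at 2 uM (on this read-out higher numbers stand for a stronger effect at the one concentration tested and lower numbers for a weaker effect), where compound 1 gives 27.6%. Compound 2 `Nc1ccccc1NC(=O)c1ccc(CSC(=S)N(Cc2ccccc2)Cc2ccccc2)cc1` gives 11% in this assay, a gap to compound 1 that lies beyond the scatter. Compound 3 `Nc1ccccc1NC(=O)c1ccc(CSC(=S)N2CCN(Cc3cccnc3)CC2)cc1` has not been measured. The change from compound 1 to compound 3 is (pyridin-3-yl)methyl in place of pyridin-3-yl on an amine nitrogen in a ring. Within the data shown here, no step between measured compounds covers this change, so the expectation rests on compound 1 alone. The step of a number 4.6 percentage points lower from compound 1 to compound 3 (within the scatter) is expected to stay within the scatter. For compound 3 the estimate in this assay is 23%, with a range from 8% to 38%.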

Compound 3, a percentage reported as inhibition, at one concentration (the size of the read-out at that concentration, not a potency): 37.7%
The estimate for compound 3 lay 14.7 percentage points below the measured number, within the range that was stated.
By their numbers in this assay, from the lowest: compound 2; then compound 1; then compound 3.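

In this assay, (pyridin-3-yl)methyl in place of pyridin-3-yl on the amine nitrogen in the ring gives a number 10.1 percentage points higher from compound 1 to compound 3 (beyond the scatter), a modest step. This position therefore does not need the pyridin-3-yl ring directly on the amine nitrogen, and the read-out responds to the change. Nothing on hand gives a reason for this step.

As far as these compounds go, it remains open whether a longer chain, such as 2-(pyridin-3-yl)ethyl, would move the read-out further. A plain benzyl group at this position would show whether the nitrogen of the (pyridin-3-yl)methyl group matters.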